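The compounds below may be only part of what the source reports. "The series", "measured", "known", "first", "only" and "open" are said of these compounds alone.

Measured so far:
- compound 1 `Cn1cc(C2=C(c3nn(CCCN4CCCCC4)c4ncccc34)C(=O)N(c3cccc4ccccc34)C2=O)c2ccccc21`: 2820 nM
- compound 2 `CN(C)CCCn1nc(C2=C(c3cn(C)c4ccccc34)C(=O)N(c3ccccc3)C2=O)c2cccnc21`: 13000 nM

In a functional assay on A549 cells (Homo sapiens) for antiproliferative activity, read by MTT assay, with a stated time of 48 h (on this read-out higher numbers stand for weaker inhibition and lower numbers for stronger inhibition), compound 1 gives 2820 nM, the lowest of the two numbers; compound 2 gives 13000 nM, a gap beyond the scatter. Compound 3 `Cn1cc(C2=C(c3nn(CCCN4CCCCC4)c4ncccc34)C(=O)NC2=O)c2ccccc21` is not yet measured. It differs from compound 1 in one place: hydrogen in place of naphthalen-1-yl on an amide-type nitrogen in a ring. Among the measured compounds shown here, no step between measured compounds of this kind is available, so the direction is open; the change removes a large group from the ring nitrogen, and the expected step of a 1.6-fold higher number from compound 1 to compound 3 (0.20 log units; within the scatter) is a modest weakening, possibly none beyond the scatter. For compound 3 the estimate in this assay is 4500 nM, within 1200 nM to 16000 nM.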

Compound 3, half-maximal inhibitory concentration: > 100000 nM
Compound 3 was reported as a limit (the forecaster's own chance of this, stated with the estimate: 10%); at least 22-fold (1.34 log units) between middle value and limit.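

In this assay, the amide-type nitrogen in the five-membered ring proves to be a sensitive position: hydrogen in place of naphthalen-1-yl gives an at least 35-fold higher number from compound 1 to compound 3 (1.54 log units; beyond the scatter). Among the compounds shown here, this is the first single-place reading of that nitrogen, as compound 1 and compound 2 differ in more than one place. The value of compound 3 is a limit of the assay, not a number: the limit of > 100000 nM in this assay, at which 1 of the 3 values shown sits.

Still open, going by these compounds, is whether a methyl group, a benzyl group or a short chain ending in a carboxylic acid on that nitrogen would stay close to compound 1. The compounds shown also leave open whether both six-membered aromatic rings of naphthalen-1-yl are needed.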